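A few compounds are considered here, and "the series" means these few. Any claim that something is new, unique, unknown or untested is made for them only; others in the source may bear on it.

Working notes on the series. Compound 3 `C[C@@H](O[C@H]1CN2C(=O)C=C(c3cc[nH]c(=O)c3)CC2[C@@H]1c1ccc(F)cc1)c1cc(C(F)(F)F)cc(C(F)(F)F)c1` stands lowest of the three numbers in hand: in an assay on CHO cells for displacement of a labelled ligand from Substance-P receptor (Homo sapiens), in the presence of a further agent that is not named here (on this read-out higher numbers stand for weaker inhibition and lower numbers for stronger inhibition), compound 3 gives 3.9 nM. Compound 1 `Cc1cc(C2=CC(=O)N3C[C@H](O[C@H](C)c4cc(C(F)(F)F)cc(C(F)(F)F)c4)[C@@H](c4ccc(F)cc4)C3C2)ccn1` gives 34 nM in this assay, and compound 2 `COc1cc(C2=CC(=O)N3C[C@H](O[C@H](C)c4cc(C(F)(F)F)cc(C(F)(F)F)c4)[C@@H](c4ccc(F)cc4)C3C2)ccn1` gives 44 nM. The step from compound 1 to compound 2 is a 1.3-fold higher number from compound 1 to compound 2 (0.11 log units; within the scatter), a methoxy in place of a methyl on an aromatic carbon. Against compound 3 the two steps are an 8.7-fold lower number from compound 1 to compound 3 (0.94 log units; beyond the scatter) and an 11-fold lower number from compound 2 to compound 3 (1.05 log units; beyond the scatter); both exchange the group on the double-bonded ring carbon of the shared core, the same place that is varied below.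

Compound 4 `C[C@@H](O[C@H]1CN2C(=O)C=C(C3=CCOCC3)CC2[C@@H]1c1ccc(F)cc1)c1cc(C(F)(F)F)cc(C(F)(F)F)c1` changes that position again: a group of 6 heavy atoms (5 carbon, 1 oxygen; one six-membered non-aromatic ring with 1 hetero atom) in place of a group of 7 heavy atoms (5 carbon, 1 nitrogen, 1 oxygen; one six-membered aromatic ring with 1 hetero atom), on a double-bonded ring carbon. Going by the values given here, no measured step removes the hydrogen-bond donor or replaces the aromatic ring by a non-aromatic one, so the measured steps bear on this change only indirectly: in each of them, swapping the group that compound 3 carries for a six-membered aromatic ring with one hetero atom raised the number by clearly more than the scatter. The move to a non-aromatic ring with no donor is expected to raise the number as well, by a step beyond the scatter of comparable size, a 10-fold higher number from compound 3 to compound 4 (1.01 log units; beyond the scatter). Compound 4 is therefore estimated at 40 nM in this assay, with a range from 10 nM to 160 nM.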

Compound 4, half-maximal inhibitory concentration: 9.6 nM
The estimate for compound 4 lay 4.2-fold (0.62 log units) above the measured number; measured number outside the range, below it.
By their numbers in this assay, from the lowest: compound 3; then compound 4; then compounds 1 and 2 (each within the scatter of the next).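

Going by these compounds alone, the move away from the aromatic ring is tolerated better than the earlier steps suggested: replacing it with a six-membered non-aromatic ring with 1 hetero atom and 0 hydrogen-bond donors gives only a 2.5-fold higher number from compound 3 to compound 4 (0.39 log units; beyond the scatter) in this assay. The same group also compares well with the two other aromatic groups at this double-bonded ring carbon, with a 4.6-fold lower number from compound 2 to compound 4 (0.66 log units; beyond the scatter) and a 3.5-fold lower number from compound 1 to compound 4 (0.55 log units; beyond the scatter), so aromaticity at this position does not by itself order the numbers: compound 3 is aromatic and lowest, compounds 1 and 2 are aromatic and highest, and compound 4, non-aromatic, falls between them. No measurement on hand offers an explanation for this order.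

Compound 4 differs from compound 3 in both the ring type and the hydrogen-bond donor count, so the compounds shown do not separate how much of the step belongs to each change. Also open, on these data alone, is how an amine, a carboxylic acid or a longer open chain on this ring carbon would stand against the six-membered rings seen so far.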